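Methoxy on the fused benzene ring of compound 1

The compounds below may be only part of what the source reports. "The series", "measured", "known", "first", "only" and "open" are said of these compounds alone.

Compound 1 `NS(=O)(=O)c1cccc(/N=C2\NC(=O)/C(=C3/C(=O)Nc4ccccc43)S2)c1` gives 12100 nM in a functional assay on Caco-2 cells (Homo sapiens) for antiproliferative activity, read by MTT assay (a higher number here means a weaker inhibitor, a lower number a stronger inhibitor), the lowest number of the three measured and separated from both others by more than the scatter. Compound 2 `NS(=O)(=O)c1ccc(/N=C2\NC(=O)/C(=C3/C(=O)Nc4ccc(Br)cc43)S2)cc1` gives 42300 nM in this assay, and compound 3 `CN1C(=O)/C(=C2\S/C(=N/c3ccc(S(N)(=O)=O)cc3)NC2=O)c2ccccc21` gives 163000 nM. Neither differs from compound 1 in one place only, so no single step can be read from them. Compound 4 `COc1ccc2c(c1)/C(=C1/S/C(=N/c3cccc(S(N)(=O)=O)c3)NC1=O)C(=O)N2` keeps the core of compound 1 and carries methoxy in place of hydrogen on an aromatic carbon. Among the measured compounds shown here, no measured pair shows the effect of such a change on this core, so the expectation for compound 4 is a step that stays within the scatter, with a slight lean toward a higher number; the expected step is a 1.3-fold higher number from compound 1 to compound 4 (0.12 log units; within the scatter). Compound 4 is accordingly estimated at 16000 nM, within a range from 5000 nM to 50000 nM.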

Compound 4, half-maximal inhibitory concentration: 8390 nM
Compound 4: the middle estimate sits 1.9-fold (0.28 log units) above what was measured; measured number inside the range.
By their numbers in this assay, from the lowest: compounds 4 and 1 (each within the scatter of the next); then compound 2; then compound 3.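

On the core of compound 1, this assay now has a first single-place reading: methoxy in place of hydrogen on this aromatic carbon gives a 1.4-fold lower number from compound 1 to compound 4 (0.16 log units; within the scatter), so this position accepts the group without a step beyond the scatter. No available measurement accounts for this result. Still open, going by these compounds, is whether the same position accepts a longer ether chain such as ethoxy, an amine or a carboxylic acid. Also open, on these data alone, is whether methoxy gives a similar step on another aromatic carbon of this ring.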